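Hydroxy in Place of Chloro: What to Expect of Compound 4

This account rests on a few compounds, and the source may have more. Where it says the series, first, only, none or still open, it means among the compounds named here.

compound 1 `O=C(N/N=C/c1cccc(F)c1)c1cccnc1Nc1cccc(C(F)(F)F)c1`: 51.5%
compound 2 `O=C(N/N=C/c1ccc(F)cc1)c1cccnc1Nc1cccc(C(F)(F)F)c1`: 43.2%
compound 3 `O=C(N/N=C/c1cccc(Cl)c1)c1cccnc1Nc1cccc(C(F)(F)F)c1`: 76.7%

In a functional assay on the whole organism (strain Wistar) for inhibition, with Rattus norvegicus as the target, read by paw edema, with a stated time of 1 h, at a dose of 10 mg/kg by the intraperitoneal route (a higher number here means more inhibition at the dose given (going by the name of the read-out), a lower number less inhibition), compound 3 stands highest of the three numbers. The step of a number 25.2 percentage points higher from compound 1 to compound 3 (beyond the scatter) and the step of a number 33.5 percentage points higher from compound 2 to compound 3 (beyond the scatter) both lie beyond the scatter, whereas the step of a number 8.3 percentage points lower from compound 1 to compound 2 (within the scatter) does not. Compound 4 `O=C(N/N=C/c1cccc(O)c1)c1cccnc1Nc1cccc(C(F)(F)F)c1` differs from compound 3 by hydroxy in place of chloro on an aromatic carbon. Within the data shown here, no measured step exchanges chloro for hydroxy; the only step at this aromatic carbon is a number 25.2 percentage points higher from compound 1 to compound 3 (beyond the scatter), which shows that the group at this position can move the read-out by a modest amount. With chloro removed, compound 4 is expected to fall back toward the number of compound 1, giving an estimated 50% with a range from 30% to 70%. This estimate means an expected step of a number 26.7 percentage points lower from compound 3 to compound 4 (beyond the scatter) in this assay.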

Compound 4, a percentage reported as inhibition, in the whole organism at one dose (the size of the read-out at that dose, not a potency): 63.8%
The estimate for compound 4 lay 13.8 percentage points below the measured number, and the stated range covers the measured number.
By their numbers in this assay, from the lowest: compounds 2 and 1 (each within the scatter of the next); then compound 4; then compound 3.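

In this assay hydroxy on this aromatic carbon falls short of chloro, as a number 12.9 percentage points lower from compound 3 to compound 4 (beyond the scatter) shows, yet it surpasses fluoro, as a number 12.3 percentage points higher from compound 1 to compound 4 (beyond the scatter) shows. The 3-hydroxyphenyl group also gains over the 4-fluorophenyl group, as a number 20.6 percentage points higher from compound 2 to compound 4 (beyond the scatter) shows. The order here thus runs chloro, hydroxy, fluoro, so a group carrying a hydrogen-bond donor can stand above fluoro on this carbon. Nothing at hand explains this order. Going by these compounds, whether a methoxy group or an amine on this carbon would reach the level of chloro remains open.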